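Cytotoxicity notes on compounds 2 and 3

This account rests on a few compounds, and the source may have more. Where it says the series, first, only, none or still open, it means among the compounds named here.

Two compounds have been through a toxicity assay on Huh-7.5 cells (Homo sapiens) for inhibition, read by MTT assay, with a stated time of 96 h; a lower number here means that less compound is tolerated, a higher number that more compound is tolerated. Compound 1 `CCCOc1ccc(C(=O)Nc2ccc(OC)cc2)cc1NC(=O)CC` gives 106000 nM. Among the compounds with values here, compound 2 `CN1CCN(Cc2ccc(NC(=O)c3ccc(OCCCCl)c([N+](=O)[O-])c3)cn2)CC1` gives 12600 nM, the lowest of the two numbers; its only neighbour is compound 1, whose number is higher by a gap beyond the usual scatter, so compound 2 is the less tolerated of the pair.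

Compound 3 `CC1CCN(c2ccc(NC(=O)c3ccc(OCCCCl)c([N+](=O)[O-])c3)cn2)CC1` is not yet measured. It differs from compound 2 in one place: 4-methylpiperidin-1-yl in place of (4-methylpiperazin-1-yl)methyl on an aromatic carbon. Within the data shown here, no measured pair shows the effect of a change of this kind, so the size of the step rests on expectation alone. In this assay the change is expected to give a step of no more than the usual scatter, with the number for compound 3, if anything, a little lower than that of compound 2. The estimated step is a 1.3-fold lower number from compound 2 to compound 3 (0.10 log units; within the scatter). Compound 3 is expected to give 10000 nM, with a range of 4000 nM to 25000 nM.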

Compound 3, half-maximal cytotoxic concentration: 9200 nM
Compound 3: middle estimate off by 1.1-fold (0.04 log units), on the high side, within the range that was stated.
By their numbers in this assay, from the lowest: compounds 3 and 2 (each within the scatter of the next); then compound 1.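

In this assay, within the data shown here, the exchange of (4-methylpiperazin-1-yl)methyl for 4-methylpiperidin-1-yl, on an aromatic carbon next to the ring nitrogen, gives a 1.4-fold lower number from compound 2 to compound 3 (0.14 log units; within the scatter) and is the first step measured at this position. For this one pair, the ring with 2 hetero atoms and the ring with 1 hetero atom stand level within the scatter, so the exchange shows no clear effect on tolerance in these cells. No available evidence accounts for this result.

With ring and attachment exchanged together, the step leaves open what 4-methylpiperazin-1-yl or (4-methylpiperidin-1-yl)methyl would give at this place. Going by these compounds, a morpholin-4-yl group, a primary amine or a carboxylic acid at the same position also remains open.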